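This account rests on a few compounds, and the source may have more. Where it says the series, first, only, none or still open, it means among the compounds named here.

Compound 1 `CN1CCC(c2ccc3c(c2)oc(=O)n3C(=O)NCCCCc2ccccc2)CC1=O`: 0.6 h
Compound 2 `CC(C)CNC(=O)n1c(=O)oc2cc(C3CCN(C)CC3)ccc21`: 1.33 h

In an ADME assay on a cell-free system (plasma, Mus musculus) for metabolic stability, read by LC-MS, tested at 2 uM (a higher number here means that the compound lasts longer, a lower number that the compound disappears faster), compound 1 gives 0.6 h, the lower of the two numbers. Going by the values given here, the only other measured compound, compound 2, gives 1.33 h, and this gap lies beyond the scatter. Compound 2 differs from compound 1 in more than one place, so neither value shows what a single change at one place does.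

Compound 3 `CN1CCN(c2ccc3c(c2)oc(=O)n3C(=O)NCCCCc2ccccc2)CC1=O` keeps the rest of compound 1 and carries 4-methyl-3-oxopiperazin-1-yl in place of 1-methyl-2-oxopiperidin-4-yl on an aromatic carbon. Among the compounds with values here, with no measured step as a guide, no shift beyond the scatter is expected in this assay, in either direction. The expected step is a 1.2-fold higher number from compound 1 to compound 3 (0.07 log units; within the scatter). The estimate for compound 3 is 0.7 h, with an expected range from 0.3 h to 1.6 h.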

Compound 3, half-life: 0.333 h
For compound 3 the middle estimate is 2.1-fold (0.32 log units) above the measured one, and the stated range covers the measured number.
By their numbers in this assay, from the lowest: compounds 3 and 1 (each within the scatter of the next); then compound 2.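

Going by these compounds alone, the exchange of 1-methyl-2-oxopiperidin-4-yl for 4-methyl-3-oxopiperazin-1-yl on this aromatic carbon gives a 1.8-fold lower number from compound 1 to compound 3 (0.26 log units; within the scatter) in this assay, the first step in this set that isolates a single place. At this position, then, a second ring nitrogen and the added hydrogen-bond acceptor in the entering group come with no shift that can be told from the scatter. Nothing available bears on why the two compounds read this way.

The compounds shown leave open whether a morpholine ring or an open-chain amine on this aromatic carbon would move the half-life beyond the scatter. Within the data shown here, they also leave open whether this exchange would stay within the scatter with a longer chain in place of the one shared by compound 1 and compound 3.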